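The source may hold more compounds than are shown below. What is called first, only, known or untested is meant among the compounds shown, and "the series" means these compounds.

Measured compounds in a functional assay on NCI-H1975 cells (Homo sapiens) for inhibition, with a stated time of 72 h; on this read-out lower numbers stand for stronger inhibition of growth and higher numbers for weaker inhibition of growth:
Compound 1 `CN(Cc1ccc(C(=O)NO)cc1)C(=O)c1cc(Cl)c(O)cc1O` gives 68800 nM.
Compound 2 `CCN(Cc1ccc(C(=O)NO)cc1)C(=O)c1cc(Cl)c(O)cc1O` gives 13200 nM.
Compound 3 `CCN(Cc1ccc(C(=O)NO)cc1)C(=O)c1cc(C(C)C)c(O)cc1O` gives 7000 nM.

Compound 4 `CCCN(Cc1ccc(C(=O)NO)cc1)C(=O)c1cc(C(C)C)c(O)cc1O` has not yet been measured in this assay. The change from compound 1 to compound 2 is methyl in place of hydrogen on a saturated chain carbon bound to an amide-type nitrogen, and it produced a 5.2-fold lower number from compound 1 to compound 2 (0.72 log units; beyond the scatter). The step of a 1.9-fold lower number from compound 2 to compound 3 (0.28 log units; within the scatter) lies within the scatter. The difference between the cores of compound 1 and compound 3 is not broken down here. Compound 4 differs from compound 3 by methyl in place of hydrogen on a saturated chain carbon, two bonds along the chain from an amide-type nitrogen. Within the data shown here, this is the same kind of change as the one from compound 1 to compound 2, but not the same: there the methyl enters on a saturated chain carbon bound to an amide-type nitrogen, here on a saturated chain carbon two bonds along the chain from an amide-type nitrogen, so the chain reads ethyl to propyl rather than methyl to ethyl. Among the compounds shown this kind of change occurs twice, so the expectation rests on one earlier step. From compound 3 to compound 4 a smaller step is expected, a 1.6-fold lower number from compound 3 to compound 4 (0.19 log units; within the scatter), because the step of a 5.2-fold lower number from compound 1 to compound 2 (0.72 log units; beyond the scatter) was modest and the present change is cut one bond further out. Compound 4 is therefore expected to give about 4500 nM in this assay, with a likely range from 1500 nM to 12000 nM.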

Compound 4, concentration for 50% growth inhibition: 23700 nM
The estimate for compound 4 lay 5.3-fold (0.72 log units) below the measured number; measured number above the stated range.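

In this assay, the ethyl to propyl change gave a 3.4-fold higher number from compound 3 to compound 4 (0.53 log units; beyond the scatter). Set beside the methyl to ethyl change, this kind of addition did not carry over from one core to the other in either size or direction: the same change on two cores in this assay, a 5.2-fold lower number (0.72 log units; beyond the scatter) from compound 1 to compound 2 and a 3.4-fold higher number (0.53 log units; beyond the scatter) from compound 3 to compound 4, 18-fold (1.25 log units) apart, beyond the scatter of two such steps This shows that the earlier step cannot be relied on to predict this one, but it does not show what sets the two apart: they differ both in the core, with chloro in one and isopropyl in the other, and in the place of the added methyl, and the data do not separate these two differences.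

The compounds shown leave open how a methyl to ethyl change would read on the core of compound 3, and how an ethyl to propyl change would read on the core of compound 1; either pair would separate core from place. Also open, going by these compounds, is how a longer chain such as butyl, or a chain ending in an amine, would read on either core.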